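Hydroxy versus trifluoromethyl on the anilide ring

The compounds below may be only part of what the source reports. "The series", "measured", "known", "first", "only" and "open" are said of these compounds alone.

Measured so far:
compound 1, `O=C(Nc1ccccc1O)C1CCc2ccccc2N1C(=O)c1ccccc1Cl`: 44900 nM
compound 2, `O=C(Nc1ccccc1O)C1CCc2ccccc2N1C(=O)c1ccc(Cl)cc1`: 20200 nM
compound 3, `O=C(Nc1ccccc1C(F)(F)F)C1CCc2ccccc2N1C(=O)c1ccccc1`: 6500 nM

In a functional assay on HCT-15 cells (Homo sapiens) for cytotoxicity, read by sulforhodamine B assay, with a stated time of 72 h (a higher number here means a weaker inhibitor of growth, a lower number a stronger inhibitor of growth), compound 3 gives the lowest of the three numbers; compound 2 stands a 2.2-fold lower number from compound 1 to compound 2 (0.35 log units; beyond the scatter) below compound 1, and both sit well above compound 3, beyond the scatter in each case.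

Compound 4, `O=C(Nc1ccccc1O)C1CCc2ccccc2N1C(=O)c1ccccc1`, is not yet measured. The change from compound 3 reads (hydroxy in place of trifluoromethyl on an aromatic carbon). For the measured compounds named here, the one measured step, a 2.2-fold lower number from compound 1 to compound 2 (0.35 log units; beyond the scatter), concerns the other ring and does not touch the anilide substituent, so no measured step bears directly on this change. What can be said is that compound 1 and compound 2, both carrying the hydroxy anilide, sit well above compound 3, yet each also differs from compound 3 on the acyl ring, so the comparison is not clean.

The expectation for compound 4 is therefore a move upward, a 3.1-fold higher number from compound 3 to compound 4 (0.49 log units; beyond the scatter), with wide uncertainty. Compound 4 is estimated at 20000 nM, range 7000 nM to 60000 nM.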

Compound 4, concentration for 50% growth inhibition: 3830 nM
Beside the measured number, compound 4's estimate is 5.2-fold (0.72 log units) above it; the measured number lies below the stated range.
By their numbers in this assay, from the lowest: compounds 4 and 3 (each within the scatter of the next); then compound 2; then compound 1.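

Hydroxy in place of trifluoromethyl on this aromatic carbon, ortho to a large group, gives a 1.7-fold lower number from compound 3 to compound 4 (0.23 log units; within the scatter) in this assay, so these two groups cannot be told apart here despite their different size and hydrogen-bond counts. With the hydroxy anilide held constant, the high numbers of the chlorinated compounds follow the chloro on the other ring, as hydrogen in its place gives a 5.3-fold lower number from compound 2 to compound 4 (0.72 log units; beyond the scatter) and a 12-fold lower number from compound 1 to compound 4 (1.07 log units; beyond the scatter). Nothing available explains either the flat anilide step or the chloro steps.

As far as these compounds go, whether an amine, a carboxylic acid, a methoxy group or plain hydrogen at the anilide position would stay in the same range remains open. Also open, from the compounds shown here alone, is whether chloro on the other ring carries the same penalty when trifluoromethyl replaces hydroxy on the anilide.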